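The compounds below may be only part of what the source reports. "The series", "measured", "known", "first", "only" and "open" are said of these compounds alone.

In a functional assay on HT-29 cells (Homo sapiens) for inhibition, read by sulforhodamine B assay, with a stated time of 48 h (on this read-out higher numbers stand for weaker inhibition of growth and lower numbers for stronger inhibition of growth), compound 2 `CC1=CC[C@H](C(C)(C)NC(=S)N/N=C/c2ccc(Cl)cc2)CC1` gives 13600 nM. Within the data shown here, the only other compound measured, compound 1 `CC1=CC[C@H](C(C)(C)NC(=S)N/N=C/c2cccc(Cl)c2)CC1`, gives 7900 nM in this assay, and the two values sit within the scatter of each other: the step of a 1.7-fold higher number from compound 1 to compound 2 (0.24 log units; within the scatter) shows that moving the chlorine around the ring did not shift the read-out beyond what repeated measurements would show. Compound 3 `CC1=CC[C@H](C(C)(C)NC(=S)N/N=C/c2cccs2)CC1` differs from compound 2 by thiophen-2-yl in place of 4-chlorophenyl on a carbon with a double bond to nitrogen. Among the measured compounds shown here, no measured step covers an exchange of this kind, in which the six-membered ring with its chlorine gives way to a five-membered ring with a sulfur; the single step from compound 1 to compound 2 concerns only where the chlorine sits and was within the scatter. The best expectation is therefore a step of a 1.2-fold lower number from compound 2 to compound 3 (0.09 log units; within the scatter), that is no change beyond the scatter, with a wide range to cover the lack of a guide. Compound 3 is estimated at 11000 nM, between 3500 nM and 35000 nM.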

Compound 3, concentration for 50% growth inhibition: 17800 nM
Compound 3: the middle estimate sits 1.6-fold (0.21 log units) below what was measured, and the stated range covers the measured number.
By their numbers in this assay, from the lowest: compounds 1, 2 and 3 (each within the scatter of the next, the first and the last beyond it).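

In this assay, among these compounds, this carbon now carries a ring other than a chlorophenyl, so a change of ring type can be read for the first time. Among the compounds shown here, the exchange gives a 1.3-fold higher number from compound 2 to compound 3 (0.12 log units; within the scatter), and against the other chlorine placement it gives a 2.3-fold higher number from compound 1 to compound 3 (0.35 log units; beyond the scatter), the only step here beyond the scatter and a modest one. A five-membered aromatic ring with sulfur can therefore stand at this place without a change beyond the scatter from 4-chlorophenyl, while 3-chlorophenyl keeps a modest edge over it.

Nothing measured here explains these numbers. Still open, from the compounds shown here alone, is whether a ring holding nitrogen, such as pyridin-2-yl, or a phenyl ring carrying an amine or a carboxylic acid in place of the chlorine, would move the number further at this place.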